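Lengthening one chain: the step to compound 4

This account rests on a few compounds, and the source may have more. Where it says the series, first, only, none or still open, it means among the compounds named here.

Three compounds that share a core and differ in one chain have been measured in a functional assay on WRL68 cells (Homo sapiens) for cytotoxicity, read by MTT assay, with a stated time of 4 h; a higher number here means a weaker inhibitor, a lower number a stronger inhibitor. Compound 1 `CCC(=O)OC[C@H]1O[C@@H](O[C@@H]2OC=C(C(=O)OC)[C@H]3C[C@H](OC(C)=O)[C@H](C)[C@@H]23)[C@H](OC(C)=O)[C@@H](OC(C)=O)[C@@H]1OC(C)=O` gives 2.65 ug/mL, compound 2 `CCCCCCCCCCCC(=O)OC[C@H]1O[C@@H](O[C@@H]2OC=C(C(=O)OC)[C@H]3C[C@H](OC(C)=O)[C@H](C)[C@@H]23)[C@H](OC(C)=O)[C@@H](OC(C)=O)[C@@H]1OC(C)=O` gives 0.85 ug/mL, and compound 3 `CCCCCCCCCCCCCC(=O)OC[C@H]1O[C@@H](O[C@@H]2OC=C(C(=O)OC)[C@H]3C[C@H](OC(C)=O)[C@H](C)[C@@H]23)[C@H](OC(C)=O)[C@@H](OC(C)=O)[C@@H]1OC(C)=O` gives 58.5 ug/mL. Compound 3 therefore has the highest number of the three, and its steps to both others lie beyond the scatter.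

Compound 4 `CCCCCCCCCCCCCCCC(=O)OC[C@H]1O[C@@H](O[C@@H]2OC=C(C(=O)OC)[C@H]3C[C@H](OC(C)=O)[C@H](C)[C@@H]23)[C@H](OC(C)=O)[C@@H](OC(C)=O)[C@@H]1OC(C)=O` differs from it by ethyl in place of hydrogen on a saturated chain carbon, ten or more bonds along the chain from a carbonyl carbon. Among the compounds with values here, the closest precedent is the same change one step earlier, a 69-fold higher number from compound 2 to compound 3 (1.84 log units; beyond the scatter), which was large and went towards a higher number. The two longer extensions disagree in direction. The first, a 3.1-fold lower number from compound 1 to compound 2 (0.49 log units; beyond the scatter), was modest and went towards a lower number, whereas a 22-fold higher number from compound 1 to compound 3 (1.34 log units; beyond the scatter) was large and went towards a higher one. Compound 2 thus goes against any steady rise with chain length, and one precedent is thin support for a repeat at full size.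

A smaller move in the same direction is expected, namely a 1.5-fold higher number from compound 3 to compound 4 (0.19 log units; within the scatter). In this assay, compound 4 is estimated at 90 ug/mL, with an expected range from 20 ug/mL to 400 ug/mL.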

Compound 4, half-maximal inhibitory concentration: "not active" (no number reported)
The entry for compound 4 holds no number; there is nothing to compare the estimate with.
By their numbers in this assay, from the lowest: compound 2; then compound 1; then compound 3.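

In this assay, within the data shown here, compound 4 is entered as "not active" with no number, so no step from compound 3, or from any other compound, to compound 4 can be read. The compounds shown leave open how far compound 4 lies from compound 3 at 58.5 ug/mL. No other data shown bear on this result.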